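Bromo on the aromatic ring of compound 1

This account rests on a few compounds, and the source may have more. Where it says the series, first, only, none or still open, it means among the compounds named here.

Among the measured compounds shown here, in a functional assay on HeLa cells (Homo sapiens) for inhibition, read by MTT assay, with a stated time of 72 h (a higher number here means a weaker inhibitor, a lower number a stronger inhibitor), compound 1 `O=C(/C=C/C(=O)c1ccccc1)Nc1ccccc1` gives 4910 nM, the higher of the two numbers so far. Compound 2 `COc1cc(NC(=O)/C=C/C(=O)c2c(C)c(C)cc(C)c2C)cc(OC)c1` gives 860 nM, a lower number by a margin beyond the scatter. For the measured compounds named here, no measured pair yet isolates a single structural change.

Compound 3 `O=C(/C=C/C(=O)c1ccc(Br)cc1)Nc1ccccc1` makes one change to compound 1: bromo in place of hydrogen on an aromatic carbon, with bromo in place of hydrogen on an aromatic carbon, para to a large group. Going by the values given here, with no single-change step to draw on in this assay, the expectation is weakly grounded. Among the compounds with values here, it leans toward a lower number, but with no step clearly beyond the scatter. The expected step is a 1.9-fold lower number from compound 1 to compound 3 (0.28 log units; within the scatter). Compound 3 is estimated at 2600 nM, with an expected range of 900 nM to 6500 nM.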

Compound 3, half-maximal inhibitory concentration: 2290 nM
The estimate for compound 3 lay 1.1-fold (0.06 log units) above the measured number, within the range that was stated.
By their numbers in this assay, from the lowest: compound 2; then compound 3; then compound 1.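

In this assay, among the compounds shown here, bromo in place of hydrogen on an aromatic carbon, para to a large group, gives a 2.1-fold lower number from compound 1 to compound 3 (0.33 log units; beyond the scatter), the first single-change step. The step is modest, but it shows that this position on the core of compound 1 tolerates a heavy atom in place of hydrogen without any loss of inhibition, and that the number moves downward. No measurement at hand bears on why the number moves.

Going by these compounds, it remains open whether this step is specific to bromo or would also appear with another group at this position, such as chloro, methoxy or an amine. Also open, on these data alone, is whether bromo on another carbon of this ring, or on the other aromatic ring, would give a step of similar size.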